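The source may hold more compounds than are shown below. What is called first, only, known or untested is meant among the compounds shown, and "the series" means these compounds.

Compound 1 `O=C(NCCCNc1cc(-c2cn(-c3ccccc3)nc2-c2cccc(O)c2)ccn1)Nc1ccc(F)cc1`: 10800 nM
Compound 2 `O=C(NCCCNc1cc(-c2cn(-c3ccccc3)nc2-c2cccc(O)c2)ccn1)Nc1cccc(C(F)(F)F)c1`: 10100 nM
Compound 3 `COc1cccc(-c2nn(-c3ccccc3)cc2-c2ccnc(NCCCNC(=O)Nc3ccc(F)cc3)c2)c1`: not yet measured

In a functional assay on SK-OV-3 cells (Homo sapiens) for antiproliferative activity, read by sulforhodamine B assay, with a stated time of 48 h (a lower number here means a stronger inhibitor of growth, a higher number a weaker inhibitor of growth), compound 1 gives 10800 nM, and compound 2 gives 10100 nM, so the two stand within the scatter of each other. Going from compound 1 to compound 3 is the change (methyl in place of hydrogen on an oxygen on an aromatic ring), which reads hydroxy to methoxy, or 3-hydroxyphenyl to 3-methoxyphenyl. Among the measured compounds shown here, no measured step covers this change. The only one available, a 1.1-fold lower number from compound 1 to compound 2 (0.03 log units; within the scatter), puts 3-(trifluoromethyl)phenyl in place of 4-fluorophenyl on an amide-type nitrogen, which is a different place, so it bears only indirectly. With so little to go on, no step beyond the scatter is expected in this assay, and no direction is firmly supported. The expected change is a 1.1-fold higher number from compound 1 to compound 3 (0.05 log units; within the scatter). Compound 3 is estimated at 12000 nM, with an expected range of 5000 nM to 28000 nM.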

Compound 3, concentration for total growth inhibition: > 37000 nM
Compound 3: only a limit was reported; the forecaster's own chance of this, stated with the estimate: 10%; middle value at least 3.0-fold (0.48 log units) from the limit.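

In this assay, methyl in place of hydrogen on the oxygen of the 3-hydroxyphenyl gives an at least 3.4-fold higher number from compound 1 to compound 3 (0.53 log units; beyond the scatter), the only step shown so far that lies beyond the scatter. The other step, on the amide-type nitrogen, stays within the scatter at a 1.1-fold lower number from compound 1 to compound 2 (0.03 log units; within the scatter), so among these compounds only the change on the oxygen separates the numbers. Compound 3 is reported only as a limit, not as a number, so the printed step gives only the smallest size the change can have: the limit of > 37000 nM in this assay, at which 1 of the 3 values shown sits.

From the compounds shown here alone, with one pair, it remains open whether the step follows from losing the hydrogen on the oxygen or from adding the methyl. An amine or a carboxylic acid in place of the hydroxy, or an ethyl on the oxygen, would bear on that question, as would methoxy paired with 3-(trifluoromethyl)phenyl.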